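Arylamino in place of butoxy on the shared core

The compounds below may be only part of what the source reports. "The series", "measured", "known", "first", "only" and "open" are said of these compounds alone.

Compound 1 `O=C(C1=C(O)C(=O)N(CCCn2ccnc2)C1c1ccc(Br)cc1)c1ccccc1`: 31600 nM
Compound 2 `CCCCOC1=C(C(=O)c2ccccc2)C(c2ccc(Br)cc2)N(CCCn2ccnc2)C1=O`: 11600 nM
Compound 3 `NC1=C(C(=O)c2ccccc2)C(c2ccc(Br)cc2)N(CCCn2ccnc2)C1=O`: 107000 nM

In a functional assay on SAOS-2 cells (Homo sapiens) for antiproliferative activity, read by MTT assay, with a stated time of 72 h (a higher number here means a weaker inhibitor, a lower number a stronger inhibitor), compound 2 gives the lowest of the three numbers; compound 1 is nearest a 2.7-fold lower number from compound 1 to compound 2 (0.44 log units; beyond the scatter) and compound 3 furthest a 9.2-fold higher number from compound 2 to compound 3 (0.96 log units; beyond the scatter). Compound 4 `O=C(C1=C(Nc2ccc(I)cc2)C(=O)N(CCCn2ccnc2)C1c1ccc(Br)cc1)c1ccccc1` differs from compound 2 in one place: (4-iodophenyl)amino in place of butoxy on a double-bonded ring carbon. Among the compounds with values here, the only measured step touching this position in the same sense is the change to the free amine, a 9.2-fold higher number from compound 2 to compound 3 (0.96 log units; beyond the scatter), and the hydroxy step a 3.4-fold higher number from compound 1 to compound 3 (0.53 log units; beyond the scatter) points the same way. A (4-iodophenyl)amino group is not a plain amine, so the account expects a modest rise in this assay, a 1.7-fold higher number from compound 2 to compound 4 (0.24 log units; within the scatter), with wide uncertainty. Compound 4 is estimated at 20000 nM, between 5000 nM and 80000 nM.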

Compound 4, half-maximal inhibitory concentration: 23400 nM
The estimate for compound 4 lay 1.2-fold (0.07 log units) below the measured number; measured number inside the range.
By their numbers in this assay, from the lowest: compounds 2, 4 and 1 (each within the scatter of the next, the first and the last beyond it); then compound 3.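

In this assay, a nitrogen bearing an aromatic ring is tolerated on the double-bonded ring carbon: compound 4 cannot be told apart from the butoxy compound (a 2.0-fold higher number from compound 2 to compound 4 (0.30 log units; within the scatter)) or the hydroxy compound (a 1.4-fold lower number from compound 1 to compound 4 (0.13 log units; within the scatter)). Adding 4-iodophenyl to the amine nitrogen gives a 4.6-fold lower number from compound 3 to compound 4 (0.66 log units; beyond the scatter), so among these compounds the high number of compound 3 goes with the free amine alone. No measurement shown gives a reason for these steps. The compounds shown leave open whether the iodine or the aromatic ring carries this step, which a phenylamino or a (4-chlorophenyl)amino group at the same place would help separate.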